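This account rests on a few compounds, and the source may have more. Where it says the series, first, only, none or still open, it means among the compounds named here.

Working notes on the series. Three compounds built on a shared core have been run in an assay on HEK293 cells for negative allosteric modulation of metabotropic glutamate receptor 5 (Homo sapiens), read by FLIPR, with a stated time of 1 h; on this read-out higher numbers stand for weaker inhibition and lower numbers for stronger inhibition. Compound 1 `O=C1NCCc2nc(C#Cc3ccccc3F)sc21` gives only a limit of the assay in this assay, > 10000 nM. Compound 2 `CC1CC(C(=O)N2CCc3nc(C#Cc4ccccc4)sc3C2)C1` likewise gives only a limit in this assay, > 10000 nM. Compound 3 `O=C(C1CC(F)(F)C1)N1CCc2nc(C#Cc3cccc(F)c3)sc2C1` also sits at a limit in this assay, > 10000 nM. Compound 2 therefore stands where every value shown stands, at the limit of > 10000 nM in this assay, at which 3 of the 3 values shown sit, and no number separates it from compound 1 or compound 3.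

Compound 4 `O=C(C1CCCCO1)N1CCc2nc(C#Cc3ccccc3)sc2C1` has not yet been measured in this assay. It differs from compound 2 in one place: oxan-2-yl in place of 3-methylcyclobutyl on a carbonyl carbon. Nothing measured among the three compounds gives a direction for such a change. The step from compound 2 to compound 4 is expected to be a step that the limit leaves unreadable from compound 2 to compound 4, none beyond the scatter, with a limit again the likeliest outcome. For compound 4 the estimate in this assay is 15000 nM, within 3000 nM to 60000 nM.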

Compound 4, half-maximal inhibitory concentration: > 10000 nM
Compound 4 was reported as a limit; the forecaster's own chance of this, stated with the estimate: 80%; the middle value lies beyond the limit too.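

Compound 2 and compound 4 both give only a limit of the assay, so no step can be read between them: the limit of > 10000 nM in this assay, at which 4 of the 4 values shown sit.

The compounds shown leave open whether any group on the carbonyl carbon, or any other change to the shared core, would give a measurable number.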